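This account rests on a few compounds, and the source may have more. Where it says the series, first, only, none or still open, it means among the compounds named here.

Working notes on the series. Compound 1 `CN1C/C(=C\c2ccccc2)C(=O)[C@]2(C1)[C@@H](c1ccccc1)CN(C)[C@@]21C(=O)Nc2ccccc21` and compound 2 `CN1C/C(=C\c2ccccc2)C(=O)[C@]2(C1)[C@@H](c1ccccc1)CN(C)[C@@]21C(=O)N(C)c2ccccc21` share one core; compound 3 `CN1C/C(=C\c2ccc(Cl)cc2)C(=O)[C@]2(C1)[C@@H](c1ccc(Cl)cc1)CN(C)[C@@]21C(=O)Nc2ccccc21` and compound 4 `CN1C/C(=C\c2ccc(Cl)cc2)C(=O)[C@]2(C1)[C@@H](c1ccc(Cl)cc1)CN(C)[C@@]21C(=O)N(C)c2ccccc21` share another, and the difference between the two cores is not broken down here. In a functional assay on the whole organism (strain Wister albino) for inhibition, with Rattus norvegicus as the target, read by paw edema, with a stated time of 1 h, at a dose of 50 mg/kg by the intraperitoneal route (on this read-out lower numbers stand for less inhibition and higher numbers for more inhibition at the one dose given (going by the name of the read-out)), compound 1 gives 77% and compound 2 gives 68%. The change from compound 1 to compound 2 is methyl in place of hydrogen on an amide-type nitrogen in a ring, and in this assay it made a number 9 percentage points lower from compound 1 to compound 2 (within the scatter). Compound 3 gives 83.1% in this assay; set against compound 1 the two numbers lie within the scatter, while compound 2 sits lower than compound 3 by a gap beyond it. The change from compound 3 to compound 4 is methyl in place of hydrogen on an amide-type nitrogen in a ring; its place matches that of the earlier change word for word, so it is the same change, occurring twice among these compounds. For the measured compounds named here, for compound 4 a step of about a number 9.1 percentage points lower from compound 3 to compound 4 (within the scatter) in this assay is expected because the single earlier instance of this change gave a number 9 percentage points lower from compound 1 to compound 2 (within the scatter). Compound 4 is therefore estimated at 74% in this assay, within an expected range from 62% to 86%.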

Compound 4, a percentage reported as inhibition, in the whole organism at one dose (the size of the read-out at that dose, not a potency): 82.3%
Beside the measured number, compound 4's estimate is 8.3 percentage points below it; low and high end bracket the measured number.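

In this assay, methyl in place of hydrogen on an amide-type nitrogen in a ring gave a number 0.8 percentage points lower from compound 3 to compound 4 (within the scatter), and set beside the earlier instance on the other core, the two steps cannot be told apart: the same change on two cores in this assay, a number 9 percentage points lower (within the scatter) from compound 1 to compound 2 and a number 0.8 percentage points lower (within the scatter) from compound 3 to compound 4, 8.2 percentage points apart, within the scatter of two such steps. For the compounds shown here, on these two pairs, then, the change carries from the core of compound 1 to the core of compound 3 with no step on either core that stands out from the scatter. This does not show that the two steps are truly equal or that the change is without effect, and it rests on two pairs at a single dose and time, so it says nothing about other cores.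

Still open, on these data alone, is what a group other than methyl would do on that nitrogen, for example a longer chain, a benzyl group or a chain ending in an amine. Also open, as far as these compounds go, is how a methoxy group would behave in place of chlorine on the two outer benzene rings, and which of those two places matters for the values seen.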